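The source may report more compounds than this note shows. Statements on the series, on what has been measured and on what is new or still open speak of the compounds shown alone.

The three compounds measured in an assay on isolated protein for binding affinity to Sigma non-opioid intracellular receptor 1 (Rattus norvegicus) (a higher number here means a weaker inhibitor, a lower number a stronger inhibitor), span a wide range. Compound 1 `O=C(CCCN1CCCC(/C=C\c2ccccc2)C1)c1ccccc1` gives 15 nM, compound 2 `O=C(CN1CCCC(/C=C\c2ccccc2)C1)Nc1ccccc1` gives 640 nM, and compound 3 `C=CCN1CCCC(/C=C/c2ccccc2)C1` gives 4 nM. Compound 3 therefore holds the lowest number of the set: the gap to compound 1 lies beyond the usual scatter, and the gap to compound 2 is far wider still, so compound 3 stands as the strongest inhibitor among the three.

Compound 4 `C(=C/C1CCCN(Cc2ccccc2)C1)\c1ccccc1` has not yet been tested. It differs from compound 3 only in one place: phenyl in place of vinyl on a saturated chain carbon bound to an amine nitrogen in a ring. Among the compounds with values here, no measured pair shows this particular change, so no step can be read off directly. Because compound 3 already sits at 4 nM, and the change only enlarges the group on the ring nitrogen, compound 4 is expected to remain close to it, with a step of a 1.3-fold higher number from compound 3 to compound 4 (0.10 log units; within the scatter) in this assay that need not exceed the scatter. The estimated value for compound 4 in this assay is 5 nM, within a range from 1.5 nM to 20 nM.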

Compound 4, half-maximal inhibitory concentration: 10 nM
Beside the measured number, compound 4's estimate is 2.0-fold (0.30 log units) below it; the measured number falls inside the stated range.
By their numbers in this assay, from the lowest: compound 3; then compounds 4 and 1 (each within the scatter of the next); then compound 2.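

In this assay, within the data shown here, phenyl in place of vinyl on a saturated chain carbon bound to an amine nitrogen in a ring gives a 2.5-fold higher number from compound 3 to compound 4 (0.40 log units; beyond the scatter) and so provides the first direct reading of a single change at this place. The step is modest but lies beyond the usual scatter, showing that this place tolerates a six-membered aromatic ring with only a limited rise in the number, while the allyl group of compound 3 remains the better of the two. No available evidence accounts for the direction or size of this step.

On these data alone, whether a longer chain ending in phenyl would hold the number near that of compound 4 remains open. So does the effect of a methoxy group, a fluorine or an amine on the phenyl ring of the benzyl group.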